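The source may hold more compounds than are shown below. What is called first, only, known or untested is meant among the compounds shown, and "the series" means these compounds.

Working notes on the series in a functional assay on HCT-116 cells (Homo sapiens) for cytotoxicity, read by MTT assay, with a stated time of 72 h; a lower number here means a stronger inhibitor, a higher number a weaker inhibitor: compound 1 (`CCC[S+]([O-])CCCCN=C=S`) gives 3950 nM, compound 2 (`CCCC[S+]([O-])CCCCN=C=S`) gives 2810 nM and compound 3 (`CC(C)C[S+]([O-])CCCCN=C=S`) gives 2060 nM. Compound 3 therefore stands within the scatter of both others, as a 1.9-fold lower number from compound 1 to compound 3 (0.28 log units; within the scatter) and a 1.4-fold lower number from compound 1 to compound 2 (0.15 log units; within the scatter) also stay within it. The change to compound 4 (`[O-][S+](CCCCN=C=S)Cc1cccs1`) is thiophen-2-yl in place of isopropyl on a saturated chain carbon bound to a sulfur. The closest measured step at that place is a 1.4-fold lower number from compound 2 to compound 3 (0.13 log units; within the scatter). Among the measured compounds shown here, no measured compound carries a ring, so this evidence is indirect. With all three measured steps this small, no step beyond the scatter is expected in this assay, in either direction. The expected step is a 1.1-fold higher number from compound 3 to compound 4 (0.05 log units; within the scatter). Compound 4 is estimated at 2300 nM, with an expected range of 1100 nM to 4800 nM.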

Compound 4, half-maximal inhibitory concentration: 3210 nM
Compound 4: the middle estimate sits 1.4-fold (0.14 log units) below what was measured; measured number inside the range.
By their numbers in this assay, from the lowest: compounds 3, 2, 4 and 1 (each within the scatter of the next).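

In this assay, among the compounds shown here, thiophen-2-yl on a saturated chain carbon bound to a sulfur is the first ring at this place, and it stays within the scatter of the isopropyl compound (a 1.6-fold higher number from compound 3 to compound 4 (0.19 log units; within the scatter)), the propyl compound (a 1.1-fold higher number from compound 2 to compound 4 (0.06 log units; within the scatter)) and the ethyl compound (a 1.2-fold lower number from compound 1 to compound 4 (0.09 log units; within the scatter)). Across these chains and this five-membered aromatic ring, the change at this place therefore shows no step beyond the scatter. Nothing available explains these steps. Going by these compounds, whether an amine, a carboxylic acid or a longer chain at this place would give a step beyond the scatter remains open.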